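Benzoxazole for benzisoxazole: expected effect on fibroblast toxicity

The compounds below may be only part of what the source reports. "The series", "measured", "known", "first", "only" and "open" are said of these compounds alone.

Measured compounds:
compound 1, `c1ccc(-c2ccc(Cn3cncc3CNc3ccc(-c4onc5ccccc45)c(-c4ccccc4)c3)cc2)cc1`, with > 10000 nM in a toxicity assay on NIH3T3 cells (Mus musculus) for cytotoxicity, read by resazurin assay; a lower number here means that less compound is needed, a higher number that more compound is needed for the effect
compound 2, `CCc1ccc(Cn2cncc2CNc2ccc(-c3nc4ccccc4s3)c(-c3ccccc3)c2)cc1`, with > 1000 nM in this assay

In this assay compound 1 reaches only the limit (the limit of > 10000 nM in this assay, at which 1 of the 2 values shown sits), not a number. Compound 2 likewise stops at a limit, (the limit of > 1000 nM in this assay, at which 1 of the 2 values shown sits). Thus compound 1 stands at a limit, and the one other value shown is also a limit, so no ordering between the two can be drawn. Compound 3, `c1ccc(-c2ccc(Cn3cncc3CNc3ccc(-c4nc5ccccc5o4)c(-c4ccccc4)c3)cc2)cc1`, is not yet measured. It differs from compound 1 by a group of 9 heavy atoms (7 carbon, 1 nitrogen, 1 oxygen; one five-membered aromatic ring with 2 hetero atoms, one six-membered aromatic ring of carbon only) in place of a group of 9 heavy atoms (7 carbon, 1 nitrogen, 1 oxygen; one five-membered aromatic ring with 2 hetero atoms, one six-membered aromatic ring of carbon only), on an aromatic carbon, the new group being 1,3-benzoxazol-2-yl. Within the data shown here, no measured step between two compounds is available, so the step is expected to be none beyond the scatter, with the result most likely again a limit. Compound 3 is expected to give about 15000 nM, between 5000 nM and 50000 nM. The step expected is a step that the limit leaves unreadable from compound 1 to compound 3.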

Compound 3, half-maximal effective concentration: > 10000 nM
Compound 3 ended at the assay's limit; the forecaster's own chance of this, stated with the estimate: 80%; the middle value does not contradict the limit.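

No step can be read between compound 1 and compound 3: in this assay each of the two stands at a limit, not a number. The compounds shown leave open whether placing 1,3-benzoxazol-2-yl on the core changes the concentration needed for the effect at all.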